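This account rests on a few compounds, and the source may have more. Where it says the series, first, only, none or still open, it means among the compounds named here.

Compound 1, `O=C(Nc1cccc([N+](=O)[O-])c1)C1CCCN(C(=O)c2cc(C(F)(F)F)cc(C(F)(F)F)c2)C1`, gives 9% in an ADME assay on PC-3 cells (Homo sapiens) for cytotoxicity, read by WST assay, tested at 100 uM; on this read-out lower numbers stand for less inhibition and higher numbers for more inhibition at the one concentration tested (going by the name of the read-out). Compound 2, `CS(=O)(=O)c1cccc(C(=O)N2CCCC(C(=O)Nc3ccc(Cl)cc3)C2)c1`, gives 2%.

Compound 1 and compound 2 lie within the usual scatter of each other, so neither stands apart; both show little inhibition. Compound 3, `O=C(Nc1cccc(N2CCCC2=O)c1)C1CCCN(C(=O)c2cc(C(F)(F)F)cc(C(F)(F)F)c2)C1`, has not been measured. It differs from compound 1 in one place: 2-oxopyrrolidin-1-yl in place of nitro on an aromatic carbon. Among the compounds with values here, no measured pair shows the effect of this change, so the expectation rests only on the low numbers of compound 1 and compound 2. No step beyond the scatter is expected a number 1 percentage points lower from compound 1 to compound 3 (within the scatter). Compound 3 is estimated at 8%, within 0% to 20%.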

Compound 3, a percentage reported as inhibition, at one concentration (the size of the read-out at that concentration, not a potency): 0%
For compound 3 the middle estimate is 8 percentage points above the measured one; low and high end bracket the measured number.
By their numbers in this assay, from the lowest: compounds 3, 2 and 1 (each within the scatter of the next).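

Putting 2-oxopyrrolidin-1-yl in place of nitro on this aromatic carbon gives a number 9 percentage points lower from compound 1 to compound 3 (within the scatter) in this assay on this read-out. This first measured pair for the position shows that a five-membered non-aromatic ring can stand there while inhibition stays as low as with nitro. Nothing at hand explains this result.

Going by these compounds, whether an amine or a carboxylic acid on this aromatic carbon would bring a step beyond the scatter stays open. So does whether the same replacement would read alike on another core, such as that of compound 2.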